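From Fluorophenyl to Methylphenyl on the Aromatic Nitrogen

This account rests on a few compounds, and the source may have more. Where it says the series, first, only, none or still open, it means among the compounds named here.

Within the data shown here, compound 2 `Cc1cc(=O)n(-c2cccc(F)c2)nc1C(=O)Nc1ccc(Oc2ncnc3[nH]ccc23)cc1` shows the highest of the two numbers so far in a functional assay on MCF7 cells (Homo sapiens) for cytotoxicity, read by MTT assay, with a stated time of 72 h (a higher number here means a weaker inhibitor, a lower number a stronger inhibitor), giving 9670 nM, while compound 1 `Cc1cc(=O)n(-c2ccc(F)cc2)nc1C(=O)Nc1ccc(Oc2ncnc3[nH]ccc23)cc1` gives 4800 nM; the step of a 2.0-fold higher number from compound 1 to compound 2 (0.30 log units; within the scatter) lies within the scatter. Compound 3 `Cc1ccc(-n2nc(C(=O)Nc3ccc(Oc4ncnc5[nH]ccc45)cc3)c(C)cc2=O)cc1` differs from compound 2 by 4-methylphenyl in place of 3-fluorophenyl on an aromatic nitrogen. Among the measured compounds shown here, the single measured step touches the same aromatic nitrogen but only moves a fluorine rather than replacing the ring, and it was small, so no step beyond the scatter is expected here. Compound 3 is therefore expected to give 7000 nM (range 2500 nM to 20000 nM), a step of a 1.4-fold lower number from compound 2 to compound 3 (0.14 log units; within the scatter).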

Compound 3, half-maximal inhibitory concentration: 3620 nM
The estimate for compound 3 lay 1.9-fold (0.29 log units) above the measured number, and the stated range covers the measured number.
By their numbers in this assay, from the lowest: compounds 3, 1 and 2 (each within the scatter of the next, the first and the last beyond it).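

In this assay, among these compounds, 4-methylphenyl in place of 3-fluorophenyl on the aromatic nitrogen gives a 2.7-fold lower number from compound 2 to compound 3 (0.43 log units; beyond the scatter) and is the first step at this position to pass beyond the scatter, though only modestly. Methyl in place of fluoro gives a 1.3-fold lower number from compound 1 to compound 3 (0.12 log units; within the scatter) and so does not separate 4-methylphenyl from 4-fluorophenyl. No independent measurement bears on these differences.

As far as these compounds go, it remains open whether a 3-methylphenyl would fall with compound 2 or with compound 3. From the compounds shown here alone, it is also open whether a methoxy or an amine on this phenyl ring would move the number beyond the scatter.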